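Swapping fluoro for bromo in compound 2

The source may report more compounds than this note shows. Statements on the series, on what has been measured and on what is new or still open speak of the compounds shown alone.

Compound 1 `O=[N+]([O-])c1ccc(Nc2nccc(-c3ccc(Br)cc3)n2)cc1`: 43000 nM
Compound 2 `COc1cccc(Nc2nccc(-c3ccc(F)cc3)n2)c1`: 128000 nM
Compound 3 `O=[N+]([O-])c1ccc(Nc2nccc(-c3ccc(Cl)c(Cl)c3)n2)cc1`: 500 nM

In a functional assay on HepG2 cells (Homo sapiens) for antiproliferative activity, read by MTT assay (a lower number here means a stronger inhibitor, a higher number a weaker inhibitor), compound 2 has the highest number of the three, 128000 nM, which makes it the weakest inhibitor so far. Compound 4 `COc1cccc(Nc2nccc(-c3ccc(Br)cc3)n2)c1` differs from compound 2 in one place: bromo in place of fluoro on an aromatic carbon. This is bromo in place of fluoro on an aromatic carbon, so 4-fluorophenyl becomes 4-bromophenyl.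

Within the data shown here, no measured pair makes exactly this swap. The closest evidence is an 86-fold lower number from compound 1 to compound 3 (1.93 log units; beyond the scatter), with 3,4-dichlorophenyl in place of 4-bromophenyl. That large step shows that a change on this phenyl group can go with a big shift in the number. It is a different change, however, and it was measured on compounds that differ from compound 2 elsewhere. The 4-bromophenyl group of compound 4 is also carried by compound 1, which gives 43000 nM, but it too differs elsewhere, so it is only a loose guide.

A modest move towards a lower number is therefore expected, much smaller than the step to compound 3. In this assay, the expected change is a 2.1-fold lower number from compound 2 to compound 4 (0.33 log units; beyond the scatter). The estimate for compound 4 is 60000 nM, with an expected range of 15000 nM to 180000 nM.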

Compound 4, half-maximal inhibitory concentration: 148000 nM
Beside the measured number, compound 4's estimate is 2.5-fold (0.39 log units) below it; measured number inside the range.
By their numbers in this assay, from the lowest: compound 3; then compound 1; then compounds 2 and 4 (each within the scatter of the next).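

In this assay, putting bromo in place of fluoro on this phenyl group gives a 1.2-fold higher number from compound 2 to compound 4 (0.06 log units; within the scatter) and so leaves the two compounds indistinguishable. This is the first pair shown that changes only the halogen at this place, para to a large group, and on the shared core of these two compounds the assay does not tell fluoro from bromo. The large step between compound 1 and compound 3 therefore does not mean that every change on this phenyl group goes with a big shift in the number, although nothing measured here bears on why this swap leaves the number within the scatter.

Still open, on these data alone, is whether fluoro and bromo would also read alike on the core of compound 1, and whether the 3,4-dichlorophenyl group of compound 3 would bring a similarly low number on the core of compound 2. As far as these compounds go, it is also open whether a group of a different kind at this place, such as an amine or a carboxylic acid, would move the number where the swap between these two halogens does not.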